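The source may report more compounds than this note shows. Statements on the series, on what has been measured and on what is new or still open speak of the compounds shown alone.

Compound 1 `O=C(NO)c1cccc(-c2cn([C@H]3C[C@@H](CO)N(CCCc4ccccc4)C3)nn2)c1` gives < 10% in an assay on Sf9 cells for inhibition of histone deacetylase 11 (Homo sapiens), read by fluorescence, tested at 0.5 uM (on this read-out lower numbers stand for less inhibition and higher numbers for more inhibition at the one concentration tested (going by the name of the read-out)), a limit of the assay.
Compound 2 `O=C(NO)c1cccc(-c2cn([C@@H]3C[C@H](C(=O)O)N(CCCc4ccccc4)C3)nn2)c1` gives < 10% in this assay, a limit of the assay.
Compound 3 `O=C(NO)c1cccc(-c2cn([C@@H]3C[C@@H](CO)N(CCCc4ccccc4)C3)nn2)c1` gives < 10% in this assay, a limit of the assay.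

Compound 3 thus stands at the limit, where all three measured values sit (the limit of < 10% in this assay, at which 3 of the 3 values shown sit). Compound 4 `O=C(NO)c1cccc(-c2cn([C@@H]3C[C@H](CO)N(CCCc4ccccc4)C3)nn2)c1` differs from compound 3 as follows: the two compounds have the same atoms and bonds and differ only in configuration as drawn: 1 of 2 stereo elements differ; a stereocentre at a saturated ring carbon is drawn S in compound 3 and R in compound 4. Among the compounds with values here, the only measured step of the same kind is a step that the two limits leave unreadable from compound 1 to compound 3, a change of configuration alone (the fact that compounds 1 and 3 differ only in the configuration as drawn), and its size cannot be read because of the limit of < 10% in this assay, at which 3 of the 3 values shown sit. No step beyond the scatter can therefore be foreseen in either direction in this assay. Compound 4 is expected to give 5%, with a range from 0% to 12%. The step that the limit leaves unreadable from compound 3 to compound 4 that this estimate means is expected to be nothing beyond the scatter.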

Compound 4, a percentage reported as inhibition, at one concentration (the size of the read-out at that concentration, not a potency): < 10%
Compound 4: only a limit was reported (the forecaster's own chance of this, stated with the estimate: 85%); the middle value lies beyond the limit too.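

Within the data shown here, compound 4 gives < 10% in this assay, a limit of the assay, so no step to compound 1, compound 2 or compound 3 can be read. The compounds shown leave open whether configuration, or hydroxymethyl in place of carboxy, makes any difference in this assay.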